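The source may hold more compounds than are shown below. What is called first, only, known or untested is meant among the compounds shown, and "the series" means these compounds.

The study concerns a small set of stilbene-like compounds bearing a naphthyl group. Within the data shown here, compound 1 `Cc1cc(O)c(C(=O)O)c(C=Cc2ccc3ccccc3c2)c1` is the only member of the set with a number in an ADME assay on HEK293 cells (Homo sapiens) for cytotoxicity, read by resazurin assay, with a stated time of 24 h (on this read-out higher numbers stand for lower toxicity in this test and lower numbers for higher toxicity in this test), where compound 1 gives 52000 nM. Compound 2 `Oc1cc(CCc2ccc3ccccc3c2)cc(O)c1O`, a close relative lacking the carboxy group, is recorded in this assay only as a limit, > 100000 nM. Among the measured compounds shown here, this single limit of > 100000 nM in this assay, at which 1 of the 2 values shown sits, marks the upper edge of what the test can report, so no step between compound 1 and compound 2 can be drawn, and compound 1 stands as the sole numerical reference point.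

Compound 3 `O=C(O)c1c(O)cccc1C=Cc1ccc2ccccc2c1` has not yet been measured. Its structure differs from compound 1 by a single change, (hydrogen in place of methyl on an aromatic carbon). Since the methyl is small and neither adds nor removes any hydrogen-bond donor or acceptor, no movement beyond the usual scatter of this assay is expected; the step from compound 1 to compound 3 is estimated as a 1.1-fold higher number from compound 1 to compound 3 (0.02 log units; within the scatter). Compound 3 is therefore expected to give about 55000 nM, between 25000 nM and 110000 nM.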

Compound 3, half-maximal cytotoxic concentration: 97000 nM
For compound 3 the middle estimate is 1.8-fold (0.25 log units) below the measured one; low and high end bracket the measured number.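

In this assay, hydrogen in place of methyl on the aromatic carbon para to a carboxy group gives a 1.9-fold higher number from compound 1 to compound 3 (0.27 log units; within the scatter). Among these compounds, this is the first step in the set that can be read. It shows that at this position, meta to a hydroxy group and meta to a large group, the methyl can give way to hydrogen without a shift beyond the usual scatter of the test.

As far as these compounds go, whether a different group at this position, such as an amine, a methoxy group or a longer chain, would move the number beyond the scatter stays open. Steps to compound 2 cannot be read, and the carboxy group's part in the read-out stays open with them, as compound 2 is recorded only as a limit and not a number: the limit of > 100000 nM in this assay, at which 1 of the 3 values shown sits.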